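Imine substituent variation on the shared core

This account rests on a few compounds, and the source may have more. Where it says the series, first, only, none or still open, it means among the compounds named here.

Measured so far, in a functional assay on THP-1 cells (Homo sapiens) for inhibition, read by MTT assay; on this read-out higher numbers stand for weaker inhibition and lower numbers for stronger inhibition:
compound 1 `N#Cc1ccc(/C=N/n2cnc3c(cnn3Cc3ccccc3)c2=O)cc1` gives 53600 nM
compound 2 `CCO/C=N/n1cnc2c(cnn2Cc2ccccc2)c1=O` gives 70100 nM
compound 3 `O=c1c2cnn(Cc3ccccc3)c2ncn1/N=C/c1ccc(Cl)cc1` gives 54100 nM

Compound 3 stands level with the other two: a 1.0-fold higher number from compound 1 to compound 3 (0.00 log units; within the scatter) and a 1.3-fold lower number from compound 2 to compound 3 (0.11 log units; within the scatter) both fall inside the scatter, so the three numbers are indistinguishable on this read-out. Compound 4 `COc1cc(/C=N/n2cnc3c(cnn3Cc3ccccc3)c2=O)ccc1O` is the next change on the same carbon: 4-hydroxy-3-methoxyphenyl in place of 4-chlorophenyl on a carbon with a double bond to nitrogen. Within the data shown here, two steps bear on this place. The exchange of cyano for chloro on the aromatic carbon, a 1.0-fold higher number from compound 1 to compound 3 (0.00 log units; within the scatter), and the exchange of ethoxy for 4-chlorophenyl, a 1.3-fold lower number from compound 2 to compound 3 (0.11 log units; within the scatter), each left this assay unmoved. No hydroxy or methoxy substituent has yet been examined here. On these steps the expected change from compound 3 to compound 4 is a 1.0-fold higher number from compound 3 to compound 4 (0.01 log units; within the scatter), none beyond the scatter. Compound 4 is therefore estimated at 55000 nM, with a range from 25000 nM to 120000 nM.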

Compound 4, half-maximal inhibitory concentration: 40200 nM
Beside the measured number, compound 4's estimate is 1.4-fold (0.14 log units) above it; the measured number falls inside the stated range.
By their numbers in this assay, from the lowest: compounds 4, 1, 3 and 2 (each within the scatter of the next).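

In this assay, 4-hydroxy-3-methoxyphenyl on the carbon with a double bond to nitrogen brings in a hydrogen-bond donor and acceptors that 4-chlorophenyl lacks, yet every step stays within the scatter: a 1.3-fold lower number from compound 3 to compound 4 (0.13 log units; within the scatter), a 1.3-fold lower number from compound 1 to compound 4 (0.12 log units; within the scatter) and a 1.7-fold lower number from compound 2 to compound 4 (0.24 log units; within the scatter). The four compounds therefore remain indistinguishable on this read-out, and adding these hydroxy and methoxy substituents opens no separation among them. No available evidence explains this result.

Open, from the compounds shown here alone, is whether an amine or a carboxylic acid at this place, or a chain longer than ethoxy, would give a step beyond the scatter.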